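The source may report more compounds than this note shows. Statements on the series, on what has been measured and on what is new or still open speak of the compounds shown alone.

Compound 1 `Cc1ccc(C2=NN(C3=NC(c4ccccc4)CS3)C(c3ccc4ccccc4c3)C2)cc1` gives 8940 nM in a functional assay on BGC-823 cells (Homo sapiens) for inhibition, read by CCK-8 assay, with a stated time of 48 h (a higher number here means a weaker inhibitor, a lower number a stronger inhibitor), the lowest of the two numbers in hand. Compound 2 `Fc1ccc(C2=NN(C3=NC(c4ccccc4)CS3)C(c3ccc4ccccc4c3)C2)cc1` gives 17300 nM in this assay; the step of a 1.9-fold higher number from compound 1 to compound 2 (0.29 log units; within the scatter) stays within the scatter. Compound 3 `Cc1ccc(C2=NN(C3=NC(c4ccccc4)CS3)C(c3cccc4ccccc34)C2)cc1` differs from compound 1 by naphthalen-1-yl in place of naphthalen-2-yl on a saturated ring carbon. Among the measured compounds shown here, the one measured step exchanges a group on an aromatic carbon and does not touch the saturated ring carbon, so no measured step bears directly on this change, and nothing in hand points in either direction. Expected is therefore a 1.0-fold higher number from compound 1 to compound 3 (0.00 log units; within the scatter), no step beyond the scatter. Compound 3 is estimated at 9000 nM, within 3500 nM to 25000 nM.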

Compound 3, half-maximal inhibitory concentration: 13300 nM
Compound 3: the middle estimate sits 1.5-fold (0.17 log units) below what was measured, within the range that was stated.
By their numbers in this assay, from the lowest: compounds 1, 3 and 2 (each within the scatter of the next).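

Naphthalen-1-yl in place of naphthalen-2-yl on the saturated ring carbon gives a 1.5-fold higher number from compound 1 to compound 3 (0.17 log units; within the scatter) in this assay. Among the compounds shown here, the earlier step changed only a group on an aromatic carbon, so this is the first reading at the saturated ring carbon, and it does not separate these two attachments of the naphthalene. Nothing in hand accounts for this result.

Open, from the compounds shown here alone, is whether a smaller or more polar group on this carbon, such as a pyridine, an amine or a carboxylic acid, moves the number beyond the scatter. Also open, going by these compounds, is whether naphthalen-1-yl behaves the same with fluoro in place of methyl on the aromatic carbon.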